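The compounds below may be only part of what the source reports. "The series", "measured", "known", "first", "only" and "open" are said of these compounds alone.

Three compounds of this series share one core and differ only in the group on the saturated ring carbon of the fused six-membered ring. Compound 1 `CC(C)CC1C(=O)N(C)c2cnc(Nc3ccc(S(N)(=O)=O)cc3)nc2N1C` carries isobutyl there and in an assay on Sf9 cells for inhibition of serine/threonine-protein kinase 4 (Homo sapiens), read by luminescence and ADP-Glo, with a stated time of 1 h, in the presence of a further agent that is not named here (a lower number here means a stronger inhibitor, a higher number a weaker inhibitor), compound 1 gives 77 nM. Compound 2 `CN1C(=O)C(c2ccccc2F)N(C)c2nc(Nc3ccc(S(N)(=O)=O)cc3)ncc21` carries 2-fluorophenyl, and in this assay compound 2 gives 75 nM. Compound 3 `CN1C(=O)C(c2ccccc2C(F)(F)F)N(C)c2nc(Nc3ccc(S(N)(=O)=O)cc3)ncc21` carries 2-(trifluoromethyl)phenyl, and in this assay compound 3 gives 56 nM. The three numbers sit close together: a 1.0-fold lower number from compound 1 to compound 2 (0.01 log units; within the scatter), a 1.4-fold lower number from compound 1 to compound 3 (0.14 log units; within the scatter) and a 1.3-fold lower number from compound 2 to compound 3 (0.13 log units; within the scatter), so no difference among them is secured.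

Compound 4 `Cc1c(F)cccc1C1C(=O)N(C)c2cnc(Nc3ccc(S(N)(=O)=O)cc3)nc2N1C` continues the aryl replacements at the same place: 3-fluoro-2-methylphenyl in place of 2-(trifluoromethyl)phenyl on a saturated ring carbon. Among the compounds with values here, the steps that bear on it are the two aryl-for-isobutyl swaps and the fluoro-to-trifluoromethyl swap, each within the scatter. Within the data shown here, nothing among the measured compounds points to a move in this assay beyond the scatter from this change, in either direction, because a 1.4-fold lower number from compound 1 to compound 3 (0.14 log units; within the scatter) and a 1.3-fold lower number from compound 2 to compound 3 (0.13 log units; within the scatter) were both flat. For compound 4 the expected outcome in this assay is therefore a step of about a 1.1-fold higher number from compound 3 to compound 4 (0.03 log units; within the scatter), which is to say no secured change. The estimate for compound 4 in this assay is 60 nM, with a range from 25 nM to 150 nM.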

Compound 4, half-maximal inhibitory concentration: 419 nM
Beside the measured number, compound 4's estimate is 7.0-fold (0.84 log units) below it; measured number outside the range, above it.
By their numbers in this assay, from the lowest: compounds 3, 2 and 1 (each within the scatter of the next); then compound 4.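

At the saturated ring carbon, the group is not freely interchangeable in this assay: there is a 7.5-fold higher number from compound 3 to compound 4 (0.87 log units; beyond the scatter), and the shift persists against the other two groups, with a 5.6-fold higher number from compound 2 to compound 4 (0.75 log units; beyond the scatter) and a 5.4-fold higher number from compound 1 to compound 4 (0.74 log units; beyond the scatter), all three steps beyond the scatter. The earlier swaps had suggested a flat position, but among the four compounds shown only 3-fluoro-2-methylphenyl separates from the rest, while isobutyl, 2-fluorophenyl and 2-(trifluoromethyl)phenyl remain within the scatter of one another, so replacing isobutyl with an aryl group does not by itself account for the higher number. No supporting measurement bears on why this one aryl group stands apart, and the numbers record the step without explaining it.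

As far as these compounds go, the swap changes two things on the aryl ring at once, so it remains open whether the higher number goes with the methyl, the fluoro or the pair; 2-methylphenyl and 3-fluorophenyl at this carbon would separate these readings. From the compounds shown here alone, how far the position tolerates groups of another kind, such as a longer alkyl chain or an aminomethylphenyl, also remains open.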